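Amide chain variation across two cores of the series

The source may report more compounds than this note shows. Statements on the series, on what has been measured and on what is new or still open speak of the compounds shown alone.

Measured compounds:
compound 1, `CCC1C(=O)N(C)c2cnc(-n3ccc4cc(C(=O)NC(C)C)ccc43)nc2N1c1ccn(C)n1`, in a functional assay on NCI-H1975 cells (Homo sapiens) for antiproliferative activity, read by CCK-8 assay, with a stated time of 72 h (on this read-out higher numbers stand for weaker inhibition of growth and lower numbers for stronger inhibition of growth), gives 12200 nM
compound 2, `CCCNC(=O)c1ccc2c(ccn2-c2ncc3c(n2)N(c2ccn(C)n2)C(CC)C(=O)N3C)c1`, in this assay gives 11000 nM
compound 3, `CC[C@@H]1C(=O)N(C)c2cnc(-n3ccc4cc(C(=O)NC(C)C)ccc43)nc2N1C1CCCC1`, in this assay gives 1840 nM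

Compound 1 and compound 2 share one core and differ only in the amide chain: propyl in place of isopropyl on an amide-type nitrogen. The step this made in this assay is a 1.1-fold lower number from compound 1 to compound 2 (0.04 log units; within the scatter), so the two values are read as equivalent and nothing is said about their order.

Compound 3 carries a different core; the difference between the cores of compound 3 and compound 1 is not broken down here. Compound 3 gives the lowest number of the three in this assay, and its distance from both compound 1 and compound 2 lies beyond the scatter, so the core change, not the amide chain, carries the observed gain on these three compounds.

Compound 4, `CCCNC(=O)c1ccc2c(ccn2-c2ncc3c(n2)N(C2CCCC2)[C@H](CC)C(=O)N3C)c1`, is not yet measured. It differs from compound 3 by propyl in place of isopropyl on an amide-type nitrogen, the same change already seen between compound 1 and compound 2, at the same place. For compound 4 the expected step in this assay is a 1.1-fold lower number from compound 3 to compound 4 (0.03 log units; within the scatter), resting on the earlier outcome a 1.1-fold lower number from compound 1 to compound 2 (0.04 log units; within the scatter), which stayed within the scatter. Compound 4 is therefore estimated at 1700 nM, with the range 800 nM to 3600 nM allowing for assay repeat variation. Whether the measured result falls in line is the next point to settle.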

Compound 4, concentration for 50% growth inhibition: 786 nM
Estimate against measurement, compound 4: 2.2-fold (0.34 log units) above; the whole stated range lies above it.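

Moving from isopropyl to propyl on the amide-type nitrogen of the core of compound 3 gives a 2.3-fold lower number from compound 3 to compound 4 (0.37 log units; beyond the scatter) in this assay, a modest step that, taken alone, lies beyond the scatter, whereas the same change on the core of compound 1 gives a 1.1-fold lower number from compound 1 to compound 2 (0.04 log units; within the scatter). Set side by side, the two steps do not differ by more than repeat measurements of two such steps allow: the same change on two cores in this assay, a 1.1-fold lower number (0.04 log units; within the scatter) from compound 1 to compound 2 and a 2.3-fold lower number (0.37 log units; beyond the scatter) from compound 3 to compound 4, 2.1-fold (0.32 log units) apart, within the scatter of two such steps The change can therefore be read as carrying over between these two cores with no demonstrated dependence on the core, but with a single pair on each core this does not show that the step is truly the same size on both, that it is larger on the core of compound 3, or that it would hold on a third core.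

Only isopropyl and propyl are shown on this nitrogen, so it remains open whether a longer chain such as butyl, a cyclopropyl group, or a chain ending in an amine or a carboxylic acid would keep, extend or lose the number reached by compound 4. Also open, going by these compounds, is whether any such chain would behave alike on both cores, which would take more than one pair per core to settle.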